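A Larger Side Chain on a Quiet Series

The source may report more compounds than this note shows. Statements on the series, on what has been measured and on what is new or still open speak of the compounds shown alone.

Compound 1 `Cc1c(-c2ccccc2)sc(N)c1C(=O)c1ccc(Cl)cc1` is one of three compounds sharing a core that were tested in an assay on CHO cells for displacement of a labelled ligand from adenosine receptor A3 (Homo sapiens), read by scintillation counting, tested at 10 uM; on this read-out higher numbers stand for more inhibition at the one concentration tested (going by the name of the read-out) and lower numbers for less inhibition. There compound 1 gives 1%. Compound 2 `COc1ccccc1-c1sc(N)c(C(=O)c2ccc(Cl)cc2)c1CC(C)(C)C` gives 1% in this assay, and compound 3 `COCCOc1ccc(-c2sc(N)c(C(=O)c3ccc(Cl)cc3)c2CC(C)(C)C)cc1` gives 1%. At the digits shown compound 1 sits level with both, within the usual scatter of repeated measurements, so nothing here separates one from another.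

Compound 4 `CC(C)(C)Cc1c(-c2ccccc2)sc(N)c1C(=O)c1ccc(Cl)cc1` has not yet been measured. It differs from compound 1 by tert-butyl in place of hydrogen on a saturated chain carbon bound to an aromatic carbon. Compound 2 already carries a neopentyl chain and gives 1%; compound 3 carries the same chain and gives 1%. A step of none beyond the scatter is therefore expected in this assay. The expected step of no change at the digits printed from compound 1 to compound 4 (within the scatter) is none beyond the scatter. Compound 4 is estimated at 1%, with a range from -8% to 10%.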

Compound 4, a percentage reported as inhibition, at one concentration (the size of the read-out at that concentration, not a potency): 1%
Beside the measured number, compound 4's estimate shows no gap at the digits printed, and the stated range covers the measured number.
By their numbers in this assay, from the lowest: compounds 1, 2, 3 and 4 (each within the scatter of the next).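

In this assay tert-butyl in place of hydrogen on a saturated chain carbon bound to an aromatic carbon gives no change at the digits printed from compound 1 to compound 4 (within the scatter) as a single change, which compounds 1, 2 and 3 alone could not show. With the neopentyl chain held in place, hydrogen in place of methoxy on an aromatic carbon gives no change at the digits printed from compound 2 to compound 4 (within the scatter) and hydrogen in place of 2-methoxyethoxy gives no change at the digits printed from compound 3 to compound 4 (within the scatter) in the same read-out. So neither of these aromatic groups separates itself from hydrogen here.

As far as these compounds go, whether an amine or a carboxylic acid on that chain would read differently in this assay stays open. No supporting measurement here explains why these values coincide.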